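Methylcarbamoyl for carboxy on two related cores

The source may report more compounds than this note shows. Statements on the series, on what has been measured and on what is new or still open speak of the compounds shown alone.

Measured compounds:
compound 1 `Cc1cc(=O)c(O)c(C(=O)O)o1`: 27%
compound 2 `Cc1cc(C(=O)O)c(O)c(=O)[nH]1`: 64%
compound 3 `CNC(=O)c1oc(C)cc(=O)c1O`: 24%

In an assay on isolated protein for inhibition of methionine aminopeptidase 2 (Homo sapiens), read by fluorescence, tested at 200 uM (on this read-out lower numbers stand for less inhibition and higher numbers for more inhibition at the one concentration tested (going by the name of the read-out)), compound 2 stands highest of the three, and its gap to compound 1 and to compound 3 lies beyond the scatter in both cases. The difference between the core of compound 1 and the core of compound 2 is not broken down here.

One change is seen once in the measured set. From compound 1 to compound 3 the change is methylamino in place of hydroxy on a carbonyl carbon, and in this assay it gives a number 3 percentage points lower from compound 1 to compound 3 (within the scatter). The two values are therefore not distinguished by this read-out.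

Compound 4 `CNC(=O)c1cc(C)[nH]c(=O)c1O` is not yet measured. It differs from compound 2 by methylamino in place of hydroxy on a carbonyl carbon, the same change as from compound 1 to compound 3, at a place described in the same words for both pairs. Within the data shown here, the only step observed for this change, a number 3 percentage points lower from compound 1 to compound 3 (within the scatter), is small, and the expectation for the new pair rests on that single step; a second core with a higher starting value may behave differently, so the range is kept wide. The expected step is a number 4 percentage points lower from compound 2 to compound 4 (within the scatter). Compound 4 is estimated at 60%, with a range from 45% to 72%.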

Compound 4, a percentage reported as inhibition, at one concentration (the size of the read-out at that concentration, not a potency): 3%
For compound 4 the middle estimate is 57 percentage points above the measured one; measured number outside the range, below it.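

In this assay, the change from carboxy to methylcarbamoyl gives a number 61 percentage points lower from compound 2 to compound 4 (beyond the scatter), whereas on the other core it gives a number 3 percentage points lower from compound 1 to compound 3 (within the scatter), so the size of the step does not carry over from one core to the other: the same change on two cores in this assay, a number 3 percentage points lower (within the scatter) from compound 1 to compound 3 and a number 61 percentage points lower (beyond the scatter) from compound 2 to compound 4, 58 percentage points apart, beyond the scatter of two such steps For these two pairs, the outcome of this change depends on the core that carries it, and a step read on the core of compound 1 gives no usable guide to the step on the core of compound 2. This does not show which difference between the two cores sets the outcome, and with one pair per core it gives no rule for any further core in the series.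

On these data alone, on the core of compound 2, it remains open whether the large step is particular to methylamino or extends to other groups on the same carbonyl carbon, such as amino, dimethylamino or a longer chain like ethylamino. As far as these compounds go, it also remains open whether methoxy in place of hydroxy, which gives a methyl ester, follows the same course on both cores.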